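A few compounds are considered here, and "the series" means these few. Any claim that something is new, unique, unknown or untested is made for them only; others in the source may bear on it.

Working notes on the series. Three compounds share one core. Compound 1 `CC1=C(C(=O)OCC(C)C)C(c2ccoc2)NC(=O)N1` carries an isobutoxy group on the carbonyl carbon, compound 2 `CC1=C(C(N)=O)C(c2ccoc2)NC(=O)N1` an amino group there, compound 3 `CCN(CC)C(=O)C1=C(C)NC(=O)NC1c1ccoc1` a diethylamino group. In an assay on membranes from HeLa cells for displacement of a labelled ligand from adenosine receptor A3 (Homo sapiens), read by scintillation counting, with a stated time of 180 min, tested at 1 uM (on this read-out lower numbers stand for less inhibition and higher numbers for more inhibition at the one concentration tested (going by the name of the read-out)), compound 1 gives 16%, compound 2 gives 2% and compound 3 gives 37%. Compound 3 stands highest of the three numbers: a number 21 percentage points higher from compound 1 to compound 3 (beyond the scatter), and a number 35 percentage points higher from compound 2 to compound 3 (beyond the scatter), each beyond the scatter. The remaining step is smaller, a number 14 percentage points lower from compound 1 to compound 2 (beyond the scatter).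

Compound 4 `CC1=C(C(=O)OC2CCCC2)C(c2ccoc2)NC(=O)N1` is not yet measured. It differs from compound 3 in one place: cyclopentyloxy in place of diethylamino on a carbonyl carbon. The step that bears on it is a number 21 percentage points higher from compound 1 to compound 3 (beyond the scatter), the exchange of an oxygen-linked group for diethylamino; compound 4 makes the reverse kind of exchange, back to an oxygen-linked group, so a drop of roughly that size is expected, landing near the number of compound 1. The expected step is a number 19 percentage points lower from compound 3 to compound 4 (beyond the scatter). For compound 4 the estimate in this assay is 18%, with a range from 5% to 35%.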

Compound 4, a percentage reported as inhibition, at one concentration (the size of the read-out at that concentration, not a potency): 1%
Compound 4: the middle estimate sits 17 percentage points above what was measured; the measured number lies below the stated range.
By their numbers in this assay, from the lowest: compounds 4 and 2 (each within the scatter of the next); then compound 1; then compound 3.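

With cyclopentyloxy in place of isobutoxy on the carbonyl carbon, this assay shows a clear change (a number 15 percentage points lower from compound 1 to compound 4 (beyond the scatter)), so the number at this position depends on the group on the oxygen and not only on the linking atom. Cyclopentyloxy also separates sharply from diethylamino (a number 36 percentage points lower from compound 3 to compound 4 (beyond the scatter)) but cannot be told apart from amino (a number 1 percentage points lower from compound 2 to compound 4 (within the scatter)), so the amide and ester groups shown do not fall into two separate levels. No measurement is at hand that accounts for these differences.

Still open, as far as these compounds go, is whether the ring or the oxygen link matters in cyclopentyloxy, which a pyrrolidine amide on the same carbonyl carbon would help separate from diethylamino. A free carboxylic acid or a longer chain on the amide nitrogen at this position also remains unexplored in the compounds shown.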